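The compounds below may be only part of what the source reports. "The series", "measured", "known", "first", "only" and "open" are said of these compounds alone.

Compound 1, `COc1cccc(CSc2nnc([C@@H](C)c3ccc4cc(OC)ccc4c3)n2-c2ccc(F)cc2)c1`: 211000 nM
Compound 2, `COc1ccc2cc([C@H](C)c3nnc(SCc4c(C)cc(C)cc4C)n3-c3cccc(Cl)c3)ccc2c1`: 16300 nM

Of the compounds shown here, two have so far been tested in a functional assay on PC-3 cells (Homo sapiens) for cytotoxicity, read by MTT assay; on this read-out lower numbers stand for stronger inhibition and higher numbers for weaker inhibition. Compound 2 stands at the lower, and so stronger, end of the two numbers with 16300 nM. Compound 1 gives 211000 nM, a gap that lies well beyond the usual scatter of such measurements. The two compounds differ in several places at once, so no single structural step can be read from them, and the numbers only show that compound 2 is the more potent of the pair.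

Compound 3, `COc1ccc2cc([C@H](C)c3nnc(SCc4c(Cl)cccc4Cl)n3-c3cccc(Cl)c3)ccc2c1`, has not yet been measured. It differs from compound 2 in a single place: 2,6-dichlorophenyl in place of 2,4,6-trimethylphenyl on a saturated chain carbon bound to a sulfur. Among the compounds with values here, no measured pair in this set shows what this exchange does, so the expected direction is undecided and the step is expected to be small. The estimated step of a 1.2-fold higher number from compound 2 to compound 3 (0.09 log units; within the scatter) is expected to stay within the scatter, or at most a little beyond it. Compound 3 is therefore estimated at 20000 nM in this assay, with a plausible range from 6000 nM to 60000 nM.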

Compound 3, half-maximal inhibitory concentration: 165000 nM
For compound 3 the middle estimate is 8.3-fold (0.92 log units) below the measured one, outside the stated range (above it).
By their numbers in this assay, from the lowest: compound 2; then compounds 3 and 1 (each within the scatter of the next).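

In this assay, putting 2,6-dichlorophenyl in place of 2,4,6-trimethylphenyl on a saturated chain carbon bound to a sulfur produces a 10-fold higher number from compound 2 to compound 3 (1.01 log units; beyond the scatter), a large weakening that lies beyond the scatter. Within the data shown here, this is the first comparison in the set that isolates one place, and it shows that the result here depends strongly on what decorates this ring: both groups are six-membered aromatic rings of carbon only, with no hydrogen-bond donors or acceptors and no net charge, yet the exchange of methyl groups for chlorine atoms still moves the number this far. No measurement shown here bears on the cause of this step.

The single step changes two things together, so the compounds shown cannot separate the effect of removing the methyl groups from that of adding the chlorine atoms. Also open, as far as these compounds go, is how this place would respond to other groups, such as plain phenyl, 2,6-dimethylphenyl, or a ring carrying an amine or a carboxylic acid.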